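Propargyl for Chloroacetyl on a Piperazine Nitrogen

The compounds below may be only part of what the source reports. "The series", "measured", "known", "first", "only" and "open" are said of these compounds alone.

Measured compounds:
compound 1 `CCN(CC)c1ccc2cc(C(=O)c3ccc(N4CCN(C(=O)CN5CCN(C(=O)CCl)CC5)CC4)cc3)oc2c1` gives 20900 nM
compound 2 `CCN(CC)c1ccc2cc(C(=O)c3ccc(N4CCN(C(=O)CN5CCN(S(=O)(=O)c6ccc(C(F)(F)F)cc6)CC5)CC4)cc3)oc2c1` gives 17000 nM

Two compounds sharing the same core have been run in an ADME assay on L02 cells (Homo sapiens) for cytotoxicity, read by MTT assay, with a stated time of 48 h; on this read-out higher numbers stand for weaker inhibition and lower numbers for stronger inhibition. Compound 1 gives 20900 nM and compound 2 gives 17000 nM; the two numbers lie within the usual scatter of each other, so compound 1 cannot be set apart from compound 2 on this read-out. Compound 3 `C#CCN1CCN(CC(=O)N2CCN(c3ccc(C(=O)c4cc5ccc(N(CC)CC)cc5o4)cc3)CC2)CC1` has not yet been measured. It differs from compound 1 in one place: propargyl in place of (chloromethyl)carbonyl on an amine nitrogen in a ring. Among the measured compounds shown here, no measured pair shows the effect of this change. Both measured compounds sit at similar values in this assay, and compound 3 is expected to stay in the same region, with a step from compound 1 to compound 3 of a 1.1-fold higher number from compound 1 to compound 3 (0.06 log units; within the scatter) that is estimated not to exceed the scatter. Compound 3 is therefore expected to give about 24000 nM, in a range of 10000 nM to 60000 nM.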

Compound 3, half-maximal inhibitory concentration: > 100000 nM
Compound 3: a limit, no number; the forecaster's own chance of this, stated with the estimate: 10%; middle value at least 4.1-fold (0.61 log units) from the limit.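

In this assay, replacing (chloromethyl)carbonyl with propargyl on this amine nitrogen in a ring gives an at least 4.7-fold higher number from compound 1 to compound 3 (0.67 log units; beyond the scatter). Among the compounds shown here, this is the first measured step for this change, and it shows that the group on this nitrogen can shift the read-out beyond the scatter, towards weaker inhibition. Compound 3 reads > 100000 nM, which is a limit of the assay and not a number.

As far as these compounds go, the full size of the step therefore stays open, as does which part of the exchange carries it, since the chlorine, the carbonyl and the triple bond all change together here. An acetyl group, a methyl group or a longer alkyl chain on the same nitrogen would be needed to separate these contributions.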